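Interleukin-2 binders: aryl amide variation in the series

The source may report more compounds than this note shows. Statements on the series, on what has been measured and on what is new or still open speak of the compounds shown alone.

compound 1 `CC(C)COc1ccc(NC(=O)CCCCCCCSc2nnc(Cc3nn(C)c(=O)c4ccccc34)n2C)cc1`: "not determined" (no result reported) in an assay on isolated protein for binding affinity to interleukin-2 (Homo sapiens), read by surface plasmon resonance; on this read-out lower numbers stand for tighter binding and higher numbers for weaker binding
compound 2 `Cn1c(Cc2nn(C)c(=O)c3ccccc23)nnc1SCCCCCCCC(=O)Nc1ccc(Cl)cc1Cl`: 8000 nM in this assay
compound 3 `CC(C)Oc1ccc(NC(=O)CCCCCCCSc2nnc(Cc3nn(C)c(=O)c4ccccc34)n2C)cc1`: "not determined" (no result reported) in this assay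

Compound 3 stands without a number in this assay, and compound 1 is the one further entry without a number, so compound 3 cannot be placed against compound 2 at all. Compound 4 `Cn1c(Cc2nn(C)c(=O)c3ccccc23)nnc1SCCCCCCCC(=O)Nc1ccc(Br)cc1Br` differs from compound 3 by 2,4-dibromophenyl in place of 4-isopropoxyphenyl on an amide-type nitrogen. Among the compounds with values here, no step between two measured compounds exists in this assay, so nothing can be said about the size or direction of the change from compound 3 to compound 4 beyond the scatter. Within the data shown here, the expectation for compound 4 therefore rests only on compound 2, the one compound with a number, at 8000 nM in this assay, and compound 2 likewise carries two halogens on the phenyl at the amide-type nitrogen. Compound 4 is expected near 8000 nM, estimated within 2500 nM to 30000 nM.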

Compound 4, dissociation constant: 10000 nM
Compound 4: the middle estimate sits 1.3-fold (0.10 log units) below what was measured; measured number inside the range.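

In this assay the series now has its first readable step, with a 1.3-fold higher number from compound 2 to compound 4 (0.10 log units; within the scatter) for 2,4-dibromophenyl in place of 2,4-dichlorophenyl on an amide-type nitrogen. At this position, this read-out does not separate the two dihalogenated phenyl groups. No measured evidence bears on this result.

The steps involving compound 1 and compound 3 cannot be read, so 4-isopropoxyphenyl remains unplaced against the dihalogenated groups. Going by these compounds, the effect of an amine or a carboxylic acid on this phenyl, or of a shorter chain before the amide, remains open.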